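Acetyl for nitrile on the pyridine arm of compound 2

This account rests on a few compounds, and the source may have more. Where it says the series, first, only, none or still open, it means among the compounds named here.

Among the compounds with values here, compound 2 `N#Cc1cccc(C#Cc2cccc(C#N)n2)c1` is the only member of this set with a measured number: in an assay on membranes from brain (strain Sprague-Dawley) for displacement of a labelled ligand from metabotropic glutamate receptor 5 (Rattus norvegicus), read by scintillation counting, with a stated time of 60 min (a lower number here means a stronger inhibitor, a higher number a weaker inhibitor), compound 2 gives 8.2 nM. Compound 1 `N#Cc1cccc(C#Cc2cccc(C(N)=O)c2)n1` sits at a limit of the assay, with > 10000 nM. Compound 3 `N#Cc1cccc(C#Cc2cc(F)cc(C(N)=O)c2)n1` likewise sits at a limit, with > 10000 nM. Within the data shown here, the one readable step, an at least 1200-fold lower number from compound 1 to compound 2 (3.08 log units; beyond the scatter), rests on (the limit of > 10000 nM in this assay, at which 2 of the 3 values shown sit), so its true size may be larger still. The step that the two limits leave unreadable from compound 1 to compound 3 gives no information.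

Compound 4 `CC(=O)c1cccc(C#Cc2cccc(C#N)c2)n1` differs from compound 2 by acetyl in place of cyano on an aromatic carbon. Among the measured compounds shown here, the only measured step that bears on it is the exchange of carbamoyl for cyano in going from compound 1 to compound 2, which moved the number enormously, though on the other ring. An acetyl entering next to the ring nitrogen also brings a carbonyl in place of a nitrile, so a weaker binder than compound 2 is expected, but with the change on a different ring the step is not expected to reach the full measured size. For compound 4 the estimated value in this assay is 150 nM, within 15 nM to 3000 nM, meaning an expected step of an 18-fold higher number from compound 2 to compound 4 (1.26 log units; beyond the scatter).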

Compound 4, inhibition constant: 114 nM
Estimate against measurement, compound 4: 1.3-fold (0.12 log units) above; the measured number falls inside the stated range.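

Within the data shown here, with a 14-fold higher number from compound 2 to compound 4 (1.14 log units; beyond the scatter) in this assay this exchange gives the first step in the set with a measured number at both ends. It shows that the aromatic carbon next to the ring nitrogen is sensitive to the group it carries, and that acetyl there weakens binding while compound 4 still gives a number and not a limit of the assay. Nothing among the measurements shown gives a cause for this step.

From the compounds shown here alone, it remains open how other groups would fare on this aromatic carbon, such as an amine, a carboxylic acid, a methyl ester or a longer ketone chain like propanoyl. The compounds shown also leave open whether carbamoyl here would behave like acetyl, and whether acetyl on the other ring would give a step of similar size.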